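A few compounds are considered here, and "the series" means these few. Any claim that something is new, unique, unknown or untested is made for them only; others in the source may bear on it.

Compound 3 `NC1=NC2(CCSCC2)N(OCCCOc2cc(Cl)c(Cl)cc2Cl)C(N)=N1` has no single number in an assay on isolated protein for inhibition of Dihydrofolate reductase (Homo sapiens), read by spectrophotometry, using NADPH, with stated times of 5 s and 6 min; on this read-out lower numbers stand for stronger inhibition and higher numbers for weaker inhibition; its entry reads "not determined" (no result reported). Compound 2 `NC1=NC2(CCSCC2)N(OCCCOc2cccc(Cl)c2Cl)C(N)=N1` likewise shows "not determined" (no result reported). Among the compounds with values here, the only number among the measured compounds comes from compound 1 `NC1=NC2(CCSCC2)N(OCCCOc2ccc(Br)cc2)C(N)=N1`, which gives 6.46 nM. Compound 4 `NC1=NC2(CCSCC2)N(OCCCOc2ccc(Cl)cc2)C(N)=N1` is reached from compound 3 by one change, (4-chlorophenyl in place of 2,4,5-trichlorophenyl on an oxygen on a saturated carbon). Within the data shown here, no step between measured compounds is available, so the size of this step in this assay cannot be read from any measured pair, and compound 3 offers no number to set against it. Compound 4 differs from compound 1 only in the halogen atom on the phenyl group, and because compound 1 gives 6.46 nM compound 4 is expected to land near that value. The estimate for compound 4 is 7 nM, with a range from 2.5 nM to 20 nM.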

Compound 4, half-maximal inhibitory concentration: 18.3 nM
The estimate for compound 4 lay 2.6-fold (0.42 log units) below the measured number, and the stated range covers the measured number.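

In this assay, chloro in place of bromo on an aromatic carbon gives a 2.8-fold higher number from compound 1 to compound 4 (0.45 log units; beyond the scatter), so the identity of the halogen on the phenyl group registers in this read-out, though modestly. Steps involving compound 2 or compound 3 cannot be read, as neither has a number. Nothing measured here accounts for the size of this step. The compounds shown leave open how a methoxy group or an amine on the phenyl group would read in this assay, and whether a longer chain on the oxygen would shift the number.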